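The source may hold more compounds than are shown below. What is called first, only, known or untested is meant among the compounds shown, and "the series" means these compounds.

Measured so far:
compound 1 `COc1cc(-c2nn(-c3cccc(NC(=O)c4cccc(C(F)(F)F)c4)c3)cc2-c2ccncc2)ccc1Cl` — > 50000 nM
compound 2 `COc1cc(-c2nn(-c3cccc(NC(=O)Nc4cccc(C(F)(F)F)c4)c3)cc2-c2ccncc2)ccc1Cl` — 3460 nM

Compound 1 `COc1cc(-c2nn(-c3cccc(NC(=O)c4cccc(C(F)(F)F)c4)c3)cc2-c2ccncc2)ccc1Cl` reaches only a limit in a functional assay on LOX IMVI cells (Homo sapiens) for inhibition, read by sulforhodamine B assay, with a stated time of 48 h; on this read-out higher numbers stand for lower toxicity in this test and lower numbers for higher toxicity in this test: the value > 50000 nM is a limit of the assay, not a number. For the measured compounds named here, compound 2 `COc1cc(-c2nn(-c3cccc(NC(=O)Nc4cccc(C(F)(F)F)c4)c3)cc2-c2ccncc2)ccc1Cl` is the only compound with a real number, and in this assay compound 2 gives 3460 nM. The one measured step, an at least 14-fold lower number from compound 1 to compound 2 (1.15 log units; beyond the scatter), goes from the amide of compound 1 to the urea of compound 2; it runs against a limit, shown by the limit of > 50000 nM in this assay, at which 1 of the 2 values shown sits, so its true size may be larger.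

Compound 3 `COc1cc(-c2nn(-c3cccc(NC(=O)c4ccc(Cl)c(C(F)(F)F)c4)c3)cc2-c2ccncc2)ccc1Cl` is the next compound. The change from compound 2 is 4-chloro-3-(trifluoromethyl)phenyl in place of (3-(trifluoromethyl)phenyl)amino on a carbonyl carbon, which takes the urea back to an amide, now carrying a chlorine on the ring. The measured step of an at least 14-fold lower number from compound 1 to compound 2 (1.15 log units; beyond the scatter) bears on this directly: removing the urea nitrogen is the reverse of that step, so a large rise in the number is expected in this assay, most likely back to the limit. Compound 3 is therefore estimated at 30000 nM (range 7000 nM to 50000 nM), a step of an 8.7-fold higher number from compound 2 to compound 3 (0.94 log units; beyond the scatter).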

Compound 3, concentration lethal to 50% of the cells: > 32500 nM
Compound 3: a limit, no number; the forecaster's own chance of this, stated with the estimate: 55%; middle value at least 1.0-fold (0.03 log units) from the limit.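

Compound 3 gives no number in this assay, only a limit: the limit of > 32500 nM in this assay, at which 1 of the 3 values shown sits.

Replacing the urea of compound 2 with an amide gives an at least 9.3-fold higher number from compound 2 to compound 3 (0.97 log units; beyond the scatter), and this step also adds a chloro group to the ring, so it carries two changes at once. Among the three compounds shown, the two amides, compound 1 and compound 3, both stop at limits, while only the urea, compound 2, gives a real number, and adding the chloro group to the amide does not produce a measurable value in this test.

The step from compound 1 to compound 3, chloro in place of hydrogen on an aromatic carbon, cannot be read, as both ends are limits. Going by these compounds, what the chloro group contributes on its own therefore stays open, and so does how a urea carrying that chloro group, or a methyl group in its place, would behave.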